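Aryl variation on the ring nitrogen: compound 4 expected

This account rests on a few compounds, and the source may have more. Where it says the series, first, only, none or still open, it means among the compounds named here.

Values in a functional assay on HL-60 cells (Homo sapiens) for cytotoxicity, read by MTT assay, with a stated time of 48 h; a lower number here means a stronger inhibitor, a higher number a weaker inhibitor:
compound 1 `COc1ccc(-n2cc(COc3ccc4oc(=O)ccc4c3)nn2)cc1`: 46400 nM
compound 2 `O=c1ccc2cc(OCc3cn(-c4cccc(CO)c4)nn3)ccc2o1`: "not determined" (no result reported)
compound 3 `O=c1ccc2cc(OCc3cn(-c4ccc(Cl)c(Cl)c4)nn3)ccc2o1`: 47800 nM

For the measured compounds named here, only two numbers exist; compound 2 has no result. Compound 3 holds the higher of the two, yet the step between the two is a 1.0-fold higher number from compound 1 to compound 3 (0.01 log units; within the scatter), so the two are indistinguishable, and no order between them can be read.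

The next compound is compound 4 `O=c1ccc2cc(OCc3cn(-c4ccc([N+](=O)[O-])cc4)nn3)ccc2o1`. Its change from compound 3 is 4-nitrophenyl in place of 3,4-dichlorophenyl on an aromatic nitrogen. The same position has already been varied once: a 1.0-fold higher number from compound 1 to compound 3 (0.01 log units; within the scatter), where 4-methoxyphenyl gave way to 3,4-dichlorophenyl on that aromatic nitrogen without any movement beyond the scatter. That single step is the only one that bears on the present change, and it points to the aryl group on the ring nitrogen being tolerated with little effect on the number in this assay. Going by the values given here, no step in the other direction is available, so nothing argues for a shift.

Compound 4 is therefore expected to sit near compound 3 in this assay, with an estimated step of a 1.0-fold lower number from compound 3 to compound 4 (0.01 log units; within the scatter). The estimate for compound 4 is 47000 nM, with a range from 20000 nM to 110000 nM.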

Compound 4, half-maximal inhibitory concentration: 46000 nM
Compound 4: the middle estimate sits 1.0-fold (0.01 log units) above what was measured; the measured number falls inside the stated range.
By their numbers in this assay, from the lowest: compounds 4, 1 and 3 (each within the scatter of the next).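

In this assay, the aryl group on the aromatic nitrogen now spans three forms, 4-methoxyphenyl, 3,4-dichlorophenyl and 4-nitrophenyl, with no step among the listed pairs beyond the scatter. The exchange of 3,4-dichlorophenyl for 4-nitrophenyl replaces two chlorine atoms with a group bearing nitrogen and oxygen and brings in 2 hydrogen-bond acceptors where the leaving group has none, yet the number holds (a 1.0-fold lower number from compound 3 to compound 4 (0.02 log units; within the scatter)), and the direct exchange of methoxy for nitro on an aromatic carbon gives the same reading (a 1.0-fold lower number from compound 1 to compound 4 (0.00 log units; within the scatter)). No measurement on hand accounts for this flat result.

On these data alone, all three numbers belong to neutral phenyl groups on the ring nitrogen, so it remains open whether an amine or a carboxylic acid on that phenyl ring, or a longer alkyl chain in its place, would give a step beyond the scatter. Equally open, as far as these compounds go, is whether a change to the shared core, rather than to this aryl group, would move the number in this assay.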